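Amide side-chain change on the shared core of compound 1

The compounds below may be only part of what the source reports. "The series", "measured", "known", "first", "only" and "open" are said of these compounds alone.

Compound 1 `COc1ncc(-c2ccc3nc(NC(C)=O)nn3c2)cc1NS(=O)(=O)c1ccc(F)cc1` is the reference point of this small set. In a functional assay on HCT-116 cells (Homo sapiens) for antiproliferative activity, read by MTT assay, with a stated time of 48 h (on this read-out lower numbers stand for stronger inhibition and higher numbers for weaker inhibition), compound 1 gives 850 nM, the lowest of the two numbers available. Among the compounds with values here, compound 2 `COc1ncc(-c2ccc3nc(NC(C)=O)nn3c2)cc1NS(=O)(=O)c1ccc(C2CC2)cc1`, which carries cyclopropyl in place of fluoro on an aromatic carbon, gives 2220 nM in this assay; the step of a 2.6-fold higher number from compound 1 to compound 2 (0.42 log units; beyond the scatter) is the only measured comparison.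

Compound 3 `CNC(=O)CNc1nc2ccc(-c3cnc(OC)c(NS(=O)(=O)c4ccc(F)cc4)c3)cn2n1` differs from compound 1 at a different site: (methylcarbamoyl)methyl in place of acetyl on a nitrogen on an aromatic ring. Within the data shown here, the measured step from compound 1 to compound 2 concerns the fluoro position, not the acetamido group, so it gives no direct guidance for this change; it shows only that a single-group change on this core can move this assay by a modest amount. Among the measured compounds shown here, with no measured step touching the acetamido side, the expectation for compound 3 is a change of similar or smaller size in either direction, centred near no change. Compound 3 is therefore expected to give 1100 nM in this assay, within 400 nM to 3500 nM. The implied step a 1.3-fold higher number from compound 1 to compound 3 (0.11 log units; within the scatter) is expected to sit within or only just beyond the scatter.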

Compound 3, half-maximal inhibitory concentration: 4910 nM
The estimate for compound 3 lay 4.5-fold (0.65 log units) below the measured number, outside the stated range (above it).
By their numbers in this assay, from the lowest: compound 1; then compound 2; then compound 3.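

In this assay, the acetamido position proves to be a sensitive one: acetamido to ((methylcarbamoyl)methyl)amino gives a 5.8-fold higher number from compound 1 to compound 3 (0.76 log units; beyond the scatter), so this site on the shared core moves the read-out clearly beyond the scatter, just as the aromatic-carbon site does in a 2.6-fold higher number from compound 1 to compound 2 (0.42 log units; beyond the scatter). The change replaces acetyl with (methylcarbamoyl)methyl and so alters the heavy-atom count, the atom make-up and the hydrogen-bond donor count together, which means this single step cannot separate these features from one another. Nothing available accounts for the weaker result with compound 3.

Still open, going by these compounds, is whether the response at this nitrogen tracks chain length or the nature of the chain end, which an unsubstituted amine, a propionyl group or a carboxylic acid in place of the methylamide end would begin to address. Also open, on these data alone, is whether the effect of this side-chain change carries over when cyclopropyl replaces fluoro on the aromatic ring, as a compound combining both changes would show.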